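Compound 2 to compound 4: one side group exchanged

A few compounds are considered here, and "the series" means these few. Any claim that something is new, unique, unknown or untested is made for them only; others in the source may bear on it.

compound 1 `COc1ccc(OC(F)(F)F)cc1Cn1c(C(=O)NCC2(CO)CC2)cc2cc(C#N)ccc21`: < 6 mL.min-1.g-1
compound 2 `COc1ccc(C(F)(F)F)cc1Cn1c(C(=O)NCC2(CO)CC2)cc2cc(C#N)ccc21`: < 6 mL.min-1.g-1
compound 3 `COc1ccc(C(C)(C)C)cc1Cn1c(C(=O)NCC2(CO)CC2)cc2cc(C#N)ccc21`: < 6 mL.min-1.g-1

All three compounds were measured in an in vitro ADME assay on microsomes from Gut (Homo sapiens) for metabolic stability, using NADPH; on this read-out higher numbers stand for fast clearance and lower numbers for slow clearance. Compound 2 stands at < 6 mL.min-1.g-1, which is a limit and not a number. It shares this position with the other two compounds: the limit of < 6 mL.min-1.g-1 in this assay, at which 3 of the 3 values shown sit. Compound 4 `COc1ccc(C(F)(F)F)cc1Cn1c(C(=O)NCCC2(O)CCC2)cc2cc(C#N)ccc21` differs from compound 2 by one exchange: (1-hydroxycyclobutyl)methyl in place of 1-(hydroxymethyl)cyclopropyl on a saturated chain carbon bound to an amide-type nitrogen. The measured steps give no size to build on. They are a step that the two limits leave unreadable from compound 1 to compound 2 and a step that the two limits leave unreadable from compound 2 to compound 3, and both concern a different group from the one exchanged here. No step beyond the scatter is therefore expected in this assay, in either direction, and the expected step is a step that the limit leaves unreadable from compound 2 to compound 4. The estimate for compound 4 is 5 mL.min-1.g-1, with an expected range of 3 mL.min-1.g-1 to 9 mL.min-1.g-1.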

Compound 4, intrinsic clearance in microsomes: < 6 mL.min-1.g-1
Compound 4: only a limit was reported; the forecaster's own chance of this, stated with the estimate: 75%; the middle value lies beyond the limit too.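

In this assay, for the compounds shown here, compound 4 gives < 6 mL.min-1.g-1, a limit and not a number, and no step from compound 2 to compound 4 can be read. The limit is shared: the limit of < 6 mL.min-1.g-1 in this assay, at which 4 of the 4 values shown sit.

The compounds shown leave open how their clearances compare with one another, and whether exchanging this side group changes clearance at all.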